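Taking the Acetyl Off a Compound Known Only as a Limit

A few compounds are considered here, and "the series" means these few. Any claim that something is new, unique, unknown or untested is made for them only; others in the source may bear on it.

Compound 1 `CC(=O)OCCOCN1c2ccccc2C(=O)NS1(=O)=O` has been tested in a functional assay on HEL cells (Homo sapiens); on this read-out higher numbers stand for lower toxicity in this test and lower numbers for higher toxicity in this test. In this assay compound 1 gives > 200 ug/mL, which is a limit of the assay rather than a number, so only a limit is known for compound 1. Compound 2 `CC(=O)OCCOCN1c2ccccc2C(=O)N(Cc2ccccc2)S1(=O)=O` carries a benzyl in place of hydrogen on an amide-type nitrogen in a ring, and in this assay compound 2 gives 100 ug/mL. For the measured compounds named here, the step of an at least 2.0-fold lower number from compound 1 to compound 2 (0.30 log units; that floor lies within the scatter) is the only measured step, and it concerns the ring nitrogen, not the ester oxygen. Compound 3 `O=C1NS(=O)(=O)N(COCCO)c2ccccc21` differs from compound 1 by hydrogen in place of acetyl on an oxygen on a saturated carbon. Going by the values given here, no measured step bears on this change, and the single measured step touches a different position; the evidence the limit of > 200 ug/mL in this assay, at which 1 of the 2 values shown sits, shows that compound 1 itself is reported only as a limit. The step is therefore expected to be a step that the limit leaves unreadable from compound 1 to compound 3, nothing beyond the scatter. Compound 3 is expected to give 250 ug/mL in this assay, within a range from 120 ug/mL to 600 ug/mL, most likely again reported as a limit.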

Compound 3, half-maximal cytotoxic concentration: 112 ug/mL
Compound 3: the middle estimate sits 2.2-fold (0.35 log units) above what was measured, and the stated range ends above it.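

In this assay compound 3 gives 112 ug/mL, so with hydrogen in place of acetyl on this oxygen the series has a value at this position that is a number and not a limit. The change from 2-acetoxyethyl to 2-hydroxyethyl reads as an at least 1.7-fold lower number from compound 1 to compound 3 (0.25 log units; that floor lies within the scatter), which gives this position a step of its own, separate from the one at the ring nitrogen. Compound 1 stands at a limit and not a number, so this step has a floor only and its true size stays unknown: the limit of > 200 ug/mL in this assay, at which 1 of the 3 values shown sits.

The compounds shown leave open whether the read-out follows the acetyl itself or the free hydroxy, and a methyl ether, a butyryl ester or an amine at the end of the same chain could tell these apart. From the compounds shown here alone, it also remains open how the 2-hydroxyethyl chain would read with benzyl in place of hydrogen on the ring nitrogen, and whether the changes at the two positions would simply add up on the shared core.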